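Ester to ketone on the shared core: expected effect

The source may hold more compounds than are shown below. What is called first, only, known or untested is meant among the compounds shown, and "the series" means these compounds.

Measured compounds:
- compound 1 `C=C(C)[C@@H]1CC=C(Cn2cc(COc3ccccc3C3NC(=O)NC(C)=C3C(=O)OCC)nn2)CC1`: > 100000 nM
- compound 2 `C=C(C)[C@@H]1CC=C(Cn2cc(COc3ccc(C4NC(=O)NC(C)=C4C(=O)OCC)cc3OC)nn2)CC1`: 82500 nM
- compound 3 `C=C(C)[C@@H]1CC=C(Cn2cc(COc3ccc(C4NC(=O)NC(C)=C4C(C)=O)cc3)nn2)CC1`: 29000 nM

In a functional assay on MCF7 cells (Homo sapiens) for inhibition, read by sulforhodamine B assay, with a stated time of 48 h (on this read-out higher numbers stand for weaker inhibition of growth and lower numbers for stronger inhibition of growth), compound 1 gives only a limit, > 100000 nM, so no number is known for it. It sits at the limit of > 100000 nM in this assay, at which 1 of the 3 values shown sits. Compound 2 gives 82500 nM and compound 3 gives 29000 nM in this assay; these two differ in more than one place, so their values stand on their own. Compound 4 `C=C(C)[C@@H]1CC=C(Cn2cc(COc3ccccc3C3NC(=O)NC(C)=C3C(C)=O)nn2)CC1` is the unmeasured partner of compound 1. The change is methyl in place of ethoxy on a carbonyl carbon, that is, ethoxycarbonyl to acetyl. Compound 4 is expected to give 80000 nM, within 30000 nM to 300000 nM, a step of an at least 1.2-fold lower number from compound 1 to compound 4 (0.09 log units; that floor lies within the scatter) that may not reach beyond the scatter.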

Compound 4, concentration for total growth inhibition: 68700 nM
Beside the measured number, compound 4's estimate is 1.2-fold (0.07 log units) above it; the measured number falls inside the stated range.
By their numbers in this assay, from the lowest: compound 3; then compounds 4 and 2 (each within the scatter of the next). At a limit, above all of these: compound 1.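

In this assay, for the compounds shown here, the change from ethoxycarbonyl to acetyl gives an at least 1.4-fold lower number from compound 1 to compound 4 (0.16 log units; that floor lies within the scatter) and so offers the first comparison at this position. Compound 1 stands only at a limit: the limit of > 100000 nM in this assay, at which 1 of the 4 values shown sits. Going by these compounds, compound 4 gives a real number (68700 nM), yet the true size of the step stays unknown.

On these data alone, whether a carboxylic acid, an amide or a longer ketone such as propanoyl on this carbonyl carbon would shift the number further remains open. So does whether ethoxycarbonyl to acetyl would act alike in compound 2.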